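This account rests on a few compounds, and the source may have more. Where it says the series, first, only, none or still open, it means among the compounds named here.

Compound 2 `CC1=NC(C)=C(C(=O)O)C(c2cccc(Cl)c2)/C1=C(\O)OC/C(C)=C/c1ccccc1` gives 680 nM in a functional assay on IMR-32 cells for inhibition of Voltage-dependent N-type calcium channel subunit alpha-1B (Homo sapiens), read by calcium flux; on this read-out lower numbers stand for stronger inhibition and higher numbers for weaker inhibition. Among the compounds with values here, of the two numbers measured so far it shows the lower, yet its only neighbour, compound 1 `CC1=NC(C)=C(C(=O)O)C(c2cccc(Cl)c2)/C1=C(\O)OC/C=C/C1CCCCC1`, gives 830 nM, and the step of a 1.2-fold lower number from compound 1 to compound 2 (0.09 log units; within the scatter) lies within the scatter, so the two cannot be told apart. Compound 3 `CC1=NC(C)=C(C(=O)O)C(c2cccc(Cl)c2)/C1=C(\O)OCC(=O)Nc1ccccc1` has not been measured yet. It differs from compound 2 by phenylcarbamoyl in place of 1-methyl-2-phenylethenyl on a saturated chain carbon bound to an oxygen on an unsaturated carbon. Within the data shown here, the single measured step, from compound 1 to compound 2, also exchanged a group at this same place and hardly moved the number. Among the measured compounds shown here, the group entering compound 3 is of a different kind from those compared there, and nothing among the measured compounds shows what such a change does. The step of a 1.2-fold higher number from compound 2 to compound 3 (0.07 log units; within the scatter) is therefore expected to stay within the scatter. For compound 3 the estimated value is 800 nM, with a range from 250 nM to 2500 nM.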

Compound 3, half-maximal inhibitory concentration: 28000 nM
Estimate against measurement, compound 3: 35-fold (1.54 log units) below, and the stated range ends below it.
By their numbers in this assay, from the lowest: compounds 2 and 1 (each within the scatter of the next); then compound 3.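

In this assay the place on a saturated chain carbon bound to an oxygen on an unsaturated carbon is not indifferent to what sits there: phenylcarbamoyl gives a 41-fold higher number from compound 2 to compound 3 (1.61 log units; beyond the scatter) and a 34-fold higher number from compound 1 to compound 3 (1.53 log units; beyond the scatter), so inhibition is much weaker with this group. The two groups exchanged between compound 2 and compound 3 have the same count of heavy atoms and the same six-membered aromatic ring, so neither that count nor the ring alone keeps the number low; what differs is the nitrogen, the oxygen and the donor and acceptor they add. Nothing measured here explains the jump.

From the compounds shown here alone, whether the amide hydrogen matters remains open, as a compound with a methyl on that nitrogen would test. What a plain benzyl group or an amine would do at this place is also unknown.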